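Aryl substituent exchange: thiophenyl in place of piperidinyl

A few compounds are considered here, and "the series" means these few. Any claim that something is new, unique, unknown or untested is made for them only; others in the source may bear on it.

Measured so far in a functional assay on trachea (Cavia porcellus); on this read-out lower numbers stand for stronger inhibition and higher numbers for weaker inhibition:
compound 1, `CCN1CC[C@@]2(OC)OC(N)=C(C#N)[C@@H](c3ccccc3)[C@@H]2C1`: 23400 nM
compound 2, `CCN1CC[C@@]2(OC)OC(N)=C(C#N)[C@@H](c3ccc(Br)cc3)[C@@H]2C1`: 13200 nM
compound 3, `CCN1CC[C@@]2(OC)OC(N)=C(C#N)[C@@H](c3ccc(N4CCCCC4)cc3)[C@@H]2C1`: 13800 nM

Compound 3 gives the second highest of the three numbers in this assay; its nearest neighbour is compound 2 and the step of a 1.0-fold higher number from compound 2 to compound 3 (0.02 log units; within the scatter) lies within the scatter, as does the step of a 1.7-fold lower number from compound 1 to compound 3 (0.23 log units; within the scatter) to the furthest compound. All three numbers are therefore indistinguishable on this read-out.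

Compound 4, `CCN1CC[C@@]2(OC)OC(N)=C(C#N)[C@@H](c3ccc(-c4cccs4)cc3)[C@@H]2C1`, differs from compound 3 in one place: thiophen-2-yl in place of piperidin-1-yl on an aromatic carbon. For the measured compounds named here, the steps that bear on this exchange are the two that alter the same aromatic carbon, a 1.8-fold lower number from compound 1 to compound 2 (0.25 log units; within the scatter) and a 1.7-fold lower number from compound 1 to compound 3 (0.23 log units; within the scatter), and the direct exchange a 1.0-fold higher number from compound 2 to compound 3 (0.02 log units; within the scatter); every one of them lies within the scatter. Going by the values given here, nothing among the measured compounds indicates that a group on this carbon moves the number beyond the scatter, so no step beyond it is expected for compound 4, in either direction: the expected step is a 1.1-fold lower number from compound 3 to compound 4 (0.03 log units; within the scatter). Compound 4 is accordingly estimated at 13000 nM in this assay, with a range from 5000 nM to 35000 nM.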

Compound 4, half-maximal inhibitory concentration: 19800 nM
Compound 4: the middle estimate sits 1.5-fold (0.18 log units) below what was measured; the measured number falls inside the stated range.
By their numbers in this assay, from the lowest: compounds 2, 3, 4 and 1 (each within the scatter of the next).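

In this assay, an aromatic five-membered thiophen-2-yl on this carbon, para to a large group, gives a number that cannot be told from that of the non-aromatic six-membered piperidin-1-yl (a 1.4-fold higher number from compound 3 to compound 4 (0.16 log units; within the scatter)). The same holds against bromo (a 1.5-fold higher number from compound 2 to compound 4 (0.18 log units; within the scatter)) and against hydrogen (a 1.2-fold lower number from compound 1 to compound 4 (0.07 log units; within the scatter)), so across the four compounds shown, even an aromatic ring at this carbon leaves every step within the scatter. Nothing at hand bears on the reason for this flat result.

Going by these compounds, whether a group of another kind on this carbon, such as a carboxylic acid, a primary amine or a longer alkyl chain, would move the number beyond the scatter remains open. Also open, on these data alone, is whether replacing the ethyl group of the shared core would do so.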